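Methyl to Methoxy: What to Expect for Compound 4

The source may report more compounds than this note shows. Statements on the series, on what has been measured and on what is new or still open speak of the compounds shown alone.

Compound 1 `Cn1cc(NC(=O)c2ccc(NS(=O)(=O)c3ccccc3)cc2)cn1` is one of three measured compounds. In a functional assay on A549 cells (Homo sapiens) for inhibition, read by MTT assay, with a stated time of 48 h (a lower number here means a stronger inhibitor, a higher number a weaker inhibitor), compound 1 gives > 100000 nM, which is a limit of the assay rather than a number. Compound 2 `O=C(Nc1cnn(-c2ccccc2)c1)c1ccc(NS(=O)(=O)c2ccccc2)cc1` in this assay gives 87100 nM. Compound 3 `Cc1ccc(-n2cc(NC(=O)c3ccc(NS(=O)(=O)c4ccccc4)cc3)cn2)cc1` in this assay gives 54700 nM.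

Within the data shown here, compound 3 therefore stands beside compound 2 as one of only two real numbers in the set, and the two cannot be told apart: a 1.6-fold lower number from compound 2 to compound 3 (0.20 log units; within the scatter). The third value, that of compound 1, sits at the limit of > 100000 nM in this assay, at which 1 of the 3 values shown sits.

Compound 4 `COc1ccc(-n2cc(NC(=O)c3ccc(NS(=O)(=O)c4ccccc4)cc3)cn2)cc1` has not yet been measured. It differs from compound 3 in one place: methoxy in place of methyl on an aromatic carbon. The measured step that bears most directly on this change is the one at the same carbon, where a methyl replaced a hydrogen, from compound 2 to compound 3: a 1.6-fold lower number from compound 2 to compound 3 (0.20 log units; within the scatter), within the scatter. The steps from compound 1, an at least 1.1-fold lower number from compound 1 to compound 2 (0.05 log units; that floor lies within the scatter) and an at least 1.8-fold lower number from compound 1 to compound 3 (0.26 log units; that floor lies within the scatter), start from a limit and set only floors, both within the scatter. None of these steps shows a change beyond the scatter at this position, so no step beyond the scatter is expected here either. The expected step is a 1.1-fold lower number from compound 3 to compound 4 (0.04 log units; within the scatter). Compound 4 is accordingly estimated at 50000 nM, with a range from 22000 nM to 110000 nM.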

Compound 4, half-maximal inhibitory concentration: 85800 nM
For compound 4 the middle estimate is 1.7-fold (0.23 log units) below the measured one; the measured number falls inside the stated range.
By their numbers in this assay, from the lowest: compounds 3, 4 and 2 (each within the scatter of the next). At a limit, above all of these: compound 1.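

Replacing the 4-methylphenyl with a 4-methoxyphenyl gives a 1.6-fold higher number from compound 3 to compound 4 (0.20 log units; within the scatter), so in this assay a group that adds an oxygen and a hydrogen-bond acceptor at this aromatic carbon produces no change that can be told apart from ordinary scatter. Methoxy in place of hydrogen gives a 1.0-fold lower number from compound 2 to compound 4 (0.01 log units; within the scatter), and with the earlier methyl step this means that two different groups at this carbon have now been compared with hydrogen, neither with a step beyond the scatter. The step with 4-methoxyphenyl in place of methyl on the aromatic nitrogen, an at least 1.1-fold lower number from compound 1 to compound 4 (0.06 log units; that floor lies within the scatter), sets only a floor, since compound 1 has a limit rather than a number: the limit of > 100000 nM in this assay, at which 1 of the 4 values shown sits.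

The compounds shown carry only hydrogen, methyl or methoxy at this carbon, so it remains open whether an amine, a carboxylic acid or a longer chain such as butoxy there would move the number beyond the scatter. The rest of the shared core stays the same in all of them, so they also leave open whether this position would respond in the same way if another part of the core were changed.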